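The source may hold more compounds than are shown below. What is called first, only, known or untested is meant among the compounds shown, and "the series" means these compounds.

Working notes on the aryl hydrazone series built on the shared core of compound 1 `CN(C)CCn1cnnc1-c1cc(Oc2ccc(NC(=O)N/N=C/c3ccc(F)cc3Cl)cc2F)ccn1`. In a functional assay on A549 cells (Homo sapiens) for cytotoxicity, read by MTT assay, with a stated time of 72 h (a lower number here means a stronger inhibitor, a higher number a weaker inhibitor), compound 1 gives 1120 nM. The companion compound 2 `CN(C)CCn1cnnc1-c1cc(Oc2ccc(NC(=O)N/N=C/c3cc(C(C)(C)C)cc(C(C)(C)C)c3O)cc2F)ccn1`, which carries a 3,5-di-tert-butyl-4-hydroxyphenyl on the same carbon, gives in this assay a value of 980 nM; the two numbers lie within the usual scatter of each other, so no order between compound 1 and compound 2 can be read from them.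

The next member, compound 3 `CN(C)CCn1cnnc1-c1cc(Oc2ccc(NC(=O)N/N=C/c3cc(Br)c(O)c(Br)c3)cc2F)ccn1`, has not yet been measured. It differs from compound 1 in one place: 3,5-dibromo-4-hydroxyphenyl in place of 2-chloro-4-fluorophenyl on a carbon with a double bond to nitrogen. For the measured compounds named here, no measured pair in the set isolates this change. Going by the values given here, the only comparison at hand, compound 1 against compound 2, shows that a hydroxyphenyl variant on this carbon sits within the scatter of the chloro-fluorophenyl parent. On that basis the expected step of a 1.2-fold lower number from compound 1 to compound 3 (0.09 log units; within the scatter) is small, with no direction beyond the scatter. Compound 3 is estimated at 900 nM in this assay, with a likely range from 300 nM to 3000 nM.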

Compound 3, half-maximal inhibitory concentration: > 100000 nM
Compound 3 ended at the assay's limit; the forecaster's own chance of this, stated with the estimate: 5%; middle value at least 110-fold (2.04 log units) from the limit.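

In this assay, the carbon with a double bond to nitrogen proves far less forgiving than compound 1 and compound 2 suggested: 3,5-dibromo-4-hydroxyphenyl in place of 2-chloro-4-fluorophenyl gives an at least 89-fold higher number from compound 1 to compound 3 (1.95 log units; beyond the scatter), a large step. The entry for compound 3, > 100000 nM, is a limit of the assay and not a number, and the step gives only a lower bound on the change: the limit of > 100000 nM in this assay, at which 1 of the 3 values shown sits A hydroxyphenyl on this carbon does not settle the outcome by itself, since compound 2, which also carries one, gives 980 nM.

As far as these compounds go, whether the loss follows the bromine, the hydroxyl or the two together stays open; a 3,5-dibromophenyl and a plain 4-hydroxyphenyl would separate them. Also open, from the compounds shown here alone, is how this carbon responds to an aryl group bearing an amine or a carboxylic acid.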